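Methylcarbamoyl in Place of 1,3-Thiazol-2-yl

This account rests on a few compounds, and the source may have more. Where it says the series, first, only, none or still open, it means among the compounds named here.

In an ADME assay on microsomes from liver (Rattus norvegicus) for metabolic stability, read by LC-MS, using NADPH, with stated times of 5 min and 30 min, at 37 degrees C (on this read-out higher numbers stand for a longer-lived compound and lower numbers for a shorter-lived compound), compound 1 `C[C@H](O)[C@@H](CCc1ccc(C(F)(F)F)cc1)n1cnc2c(N)ncnc21` gives > 0.5 h, a limit of the assay and not a number. Compound 2 `C[C@H](O)[C@@H](CCC1CCCCC1)n1cnc2c(N)ncnc21` gives a measured 0.217 h. Compound 3 `C[C@H](O)[C@@H](CCc1cccc(-c2nccs2)c1)n1cnc2c(N)ncnc21` gives > 0.5 h, again a limit and not a number. On these data alone, compound 3 therefore stands at the limit of > 0.5 h in this assay, at which 2 of the 3 values shown sit, and its true half-life remains unknown.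

The next compound is compound 4 `CNC(=O)c1cccc(CC[C@H]([C@H](C)O)n2cnc3c(N)ncnc32)c1`, which carries methylcarbamoyl in place of 1,3-thiazol-2-yl on an aromatic carbon of a six-membered aromatic ring of carbon only, meta to a large group: methylcarbamoyl in place of 1,3-thiazol-2-yl on an aromatic carbon. Going by the values given here, no measured pair isolates this change, so the size of the step in this assay has no direct precedent. No step beyond the usual scatter is expected, and no direction is favoured with confidence. The estimated step is a number no higher from compound 3 to compound 4 (the limit leaves the size open). The expected half-life of compound 4 is 0.5 h, with an estimated range from 0.2 h to 1.2 h.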

Compound 4, half-life: > 0.5 h
Compound 4 ended at the assay's limit; the forecaster's own chance of this, stated with the estimate: 50%; the middle value sits exactly at the limit.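

Compound 3 and compound 4 both rest at a limit and not at a number, so no step between them can be read: the limit of > 0.5 h in this assay, at which 3 of the 4 values shown sit.

The compounds shown leave open the true half-lives of compound 1, compound 3 and compound 4, and whether methylcarbamoyl in place of 1,3-thiazol-2-yl shifts the half-life at all.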